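The source may report more compounds than this note shows. Statements on the series, on what has been measured and on what is new or still open speak of the compounds shown alone.

Measured compounds:
- Compound 1, `O=C1CS/C(=N/Nc2nncc3ccccc23)N1c1ccccc1`: 44 nM
- Compound 2, `Cc1cc(NS(=O)(=O)c2ccc(Nc3nncc4ccccc34)cc2)no1`: 27 nM

Both compounds share a fused bicyclic core carrying an amino linkage, and both were tested in a functional assay on MDA-MB-435 cells (Homo sapiens) for antiproliferative activity, read by sulforhodamine B assay, with a stated time of 72 h; a lower number here means a stronger inhibitor, a higher number a weaker inhibitor. In this assay compound 1 gives 44 nM, while compound 2 gives 27 nM. Compound 2 has the lower of the two numbers, but its gap to compound 1 is within the usual scatter of repeated measurements, so the two compounds cannot be told apart on these data.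

Compound 3, `O=S(=O)(Nc1nccs1)c1ccc(Nc2nncc3ccccc23)cc1`, has not yet been measured. It differs from compound 2 in one place:

1,3-thiazol-2-yl in place of 5-methyl-1,2-oxazol-3-yl on a sulfonamide nitrogen

For the measured compounds named here, no step between two measured compounds is available for this kind of change, so there is no measured precedent to lean on. The two groups are of similar size, each a five-membered aromatic ring with two hetero atoms and two hydrogen-bond acceptors, and each sits on the same sulfonamide nitrogen. The expected step of a 1.3-fold higher number from compound 2 to compound 3 (0.11 log units; within the scatter) is therefore small, with no direction beyond the scatter. Compound 3 is expected to give about 35 nM in this assay, within a range from 12 nM to 100 nM.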

Compound 3, half-maximal inhibitory concentration: 36 nM
Beside the measured number, compound 3's estimate is 1.0-fold (0.01 log units) below it, within the range that was stated.
By their numbers in this assay, from the lowest: compounds 2, 3 and 1 (each within the scatter of the next).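

For the compounds shown here, this is the first measured step at this place, on a sulfonamide nitrogen whose other neighbour is the sulfonyl sulfur: 1,3-thiazol-2-yl in place of 5-methyl-1,2-oxazol-3-yl gives a 1.3-fold higher number from compound 2 to compound 3 (0.12 log units; within the scatter) in this assay. The two groups differ in their atoms, one ring holding sulfur and the other oxygen, and only the 5-methyl-1,2-oxazol-3-yl group carries a methyl, yet the two compounds cannot be told apart on this read-out. So this one swap shows that, at this place, one five-membered aromatic ring with 2 hetero atoms can take the place of the other without a measurable difference, and no measurement on hand explains why the numbers lie so close.

From the compounds shown here alone, all of this concerns just two closely similar rings, so it remains open whether a six-membered ring such as pyridin-2-yl, or a plain methyl group with no ring at all, would fit on the same nitrogen and keep the number in this range. Also open, going by these compounds, is whether a methyl group or a carboxylic acid added to the 1,3-thiazol-2-yl ring would move the number beyond the scatter.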